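Working notes: methoxycarbonyl in place of methyl

The compounds below may be only part of what the source reports. "The series", "measured", "known", "first", "only" and "open" are said of these compounds alone.

- compound 1 `Cc1ccc(-c2cccc(NC(=O)C(Cl)Cl)c2)cc1`: 8300 nM
- compound 2 `CCOc1cccc(-c2cc(NC(=O)C(Cl)Cl)cc(-c3cccc(OCC)c3)c2)c1`: 8830 nM

For the measured compounds named here, in a functional assay on A549 cells (Homo sapiens) for cytotoxicity, read by MTT assay, with a stated time of 68 h (a lower number here means a stronger inhibitor, a higher number a weaker inhibitor), compound 1 at 8300 nM and compound 2 at 8830 nM lie within the scatter of each other, so compound 1 stands level with the only other measured compound. Compound 3 `COC(=O)c1ccc(-c2cccc(NC(=O)C(Cl)Cl)c2)cc1` remains unmeasured. It carries methoxycarbonyl in place of methyl on an aromatic carbon, para to a large group (methoxycarbonyl in place of methyl on an aromatic carbon). Going by the values given here, no measured pair isolates this change, so in this assay no step beyond the scatter is expected, though with wide uncertainty. The estimated step is a 1.0-fold lower number from compound 1 to compound 3 (0.02 log units; within the scatter) and is expected to stay small. For compound 3 the expected value is 8000 nM with an estimated range from 3500 nM to 20000 nM as the working figure.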

Compound 3, half-maximal inhibitory concentration: > 50000 nM
Compound 3 ended at the assay's limit (the forecaster's own chance of this, stated with the estimate: 8%); middle value at least 6.2-fold (0.79 log units) away from the limit.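

In this assay, the position para to a large group proves sensitive to substitution: methoxycarbonyl in place of methyl gives an at least 6.0-fold higher number from compound 1 to compound 3 (0.77 log units; beyond the scatter). Compound 3 reads > 50000 nM, which is a limit of the assay and not a number, so the full size of the step stays unknown: the limit of > 50000 nM in this assay, at which 1 of the 3 values shown sits.

This single pair does not show which part of the methoxycarbonyl group matters. Open, going by these compounds, is whether a carboxylic acid, a nitrile or an ethyl group at this position would stay level with compound 1 or also reach the limit.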